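Selenium-benzyl for methylsulfanyl on the acylated amidine carbon

The source may hold more compounds than are shown below. What is called first, only, known or untested is meant among the compounds shown, and "the series" means these compounds.

Measured compounds:
Compound 1 `CS/C(=N\C(=O)c1cc2ccccc2s1)NC(=O)c1cc2ccccc2s1`: 66600 nM
Compound 2 `O=C(/N=C(/NC(=O)c1cccs1)[Se]Cc1ccccc1)c1cccs1`: 58500 nM
Compound 3 `CS/C(=N\C(=O)c1cccs1)NC(=O)c1cccs1`: a limit of the assay, > 100000 nM

All values come from a functional assay on K562 cells (Homo sapiens) for cytotoxicity, read by MTT assay, with a stated time of 72 h; on this read-out higher numbers stand for weaker inhibition of growth and lower numbers for stronger inhibition of growth. For compound 3 the value is a limit only, not a number. Among the measured compounds shown here, the one measured step, an at least 1.7-fold lower number from compound 3 to compound 2 (0.23 log units; that floor lies within the scatter), is the change (a group of 8 heavy atoms (7 carbon, 1 selenium; one six-membered aromatic ring of carbon only) in place of a group of 2 heavy atoms (1 carbon, 1 sulfur; no ring), on a carbon with a double bond to nitrogen); its size is known only as a floor because of the limit of > 100000 nM in this assay, at which 1 of the 3 values shown sits. Compound 1 has the highest of the two numbers, but its value and that of compound 2 lie within the scatter of each other. How the core of compound 1 differs from the core of compound 3 is not broken down here.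

Compound 4 `O=C(/N=C(/NC(=O)c1cc2ccccc2s1)[Se]Cc1ccccc1)c1cc2ccccc2s1` is not yet measured. From compound 1 to compound 4 the change is a group of 8 heavy atoms (7 carbon, 1 selenium; one six-membered aromatic ring of carbon only) in place of a group of 2 heavy atoms (1 carbon, 1 sulfur; no ring), on a carbon with a double bond to nitrogen, the same change as from compound 3 to compound 2, made at the same place. The step of a 1.7-fold lower number from compound 1 to compound 4 (0.22 log units; within the scatter) is expected to be small, resting on the measured step of an at least 1.7-fold lower number from compound 3 to compound 2 (0.23 log units; that floor lies within the scatter) and on the value of compound 1, 66600 nM. Compound 4 is thus estimated at 40000 nM, between 15000 nM and 100000 nM.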

Compound 4, concentration for total growth inhibition: 42800 nM
Compound 4: middle estimate off by 1.1-fold (0.03 log units), on the low side, within the range that was stated.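

In this assay, the selenium-benzyl group in place of methylsulfanyl, on a carbon with a double bond to nitrogen, gives a 1.6-fold lower number from compound 1 to compound 4 (0.19 log units; within the scatter), so on the core of compound 1 the change stays inside the usual scatter and establishes no real gain. The result is compatible with a small step on both cores, but it does not show that the two steps are equal, and neither step alone establishes an effect of the change: the same change on two cores in this assay, an at least 1.7-fold lower number (0.23 log units; that floor lies within the scatter) from compound 3 to compound 2 and a 1.6-fold lower number (0.19 log units; within the scatter) from compound 1 to compound 4; the limit leaves it open whether they differ. Compound 3 stands at > 100000 nM, which is a limit of the assay and not a number.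

Still open, going by these compounds, is how a benzylsulfanyl group or a methylselanyl group would read on either core, a comparison that would separate the selenium atom from the benzyl part. Also open, on these data alone, is how an amine or a carboxylic acid on the aromatic ring of the entering group, or a longer chain in its place, would read in this assay.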